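The compounds below may be only part of what the source reports. "The series", "measured", "known", "first", "only" and "open" are said of these compounds alone.

Compound 1 `CCOC(=O)/C=C1/C(=O)Nc2ccccc21` gives 86.9%
Compound 2 `CC(C)(C)OC(=O)/C=C1/C(=O)Nc2ccccc21` gives 87.6%
Compound 3 `CC(C)c1ccc2c(c1)/C(=C\C(=O)OC(C)(C)C)C(=O)N2` gives 87.7%

All three numbers come from a functional assay on MDA-MB-231 cells (Homo sapiens) for inhibition, read by CCK-8 assay, with a stated time of 72 h, tested at 20 uM; a lower number here means less inhibition of growth, a higher number more inhibition of growth at the concentration tested. Compound 2 sits between the other two on the numbers shown, but its steps to both lie within the scatter: a number 0.7 percentage points higher from compound 1 to compound 2 (within the scatter), and a number 0.1 percentage points higher from compound 2 to compound 3 (within the scatter). On these three measurements the ester group and the substituent on the aromatic ring leave the read-out in this assay essentially unchanged, with all three compounds grouped closely together.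

Compound 4 `COc1ccc2c(c1)NC(=O)/C2=C/C(=O)OC(C)(C)C` differs from compound 2 in one place: methoxy in place of hydrogen on an aromatic carbon. Within the data shown here, the only measured step that bears on this change is the one from compound 2 to compound 3, where a different group entered an aromatic carbon of the same ring system and the number moved by an amount within the scatter. Among the measured compounds shown here, no measured step involves a methoxy group, so nothing in the data points to a change in either direction for compound 4. The step of a number 0.1 percentage points lower from compound 2 to compound 4 (within the scatter) is therefore expected to fall within the scatter. Compound 4 is estimated to give 87.5% in this assay, with a range from 80% to 93%.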

Compound 4, percent growth inhibition at one concentration: 87.1%
The estimate for compound 4 lay 0.4 percentage points above the measured number, within the range that was stated.
By their numbers in this assay, from the lowest: compounds 1, 4, 2 and 3 (each within the scatter of the next).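

With methoxy in place of hydrogen on an aromatic carbon, meta to a fused ring and para to a fused ring, this assay records a number 0.5 percentage points lower from compound 2 to compound 4 (within the scatter), so this change at this position cannot be told apart from no change in this read-out. Among the compounds shown, this is the only substituent on the six-membered aromatic ring that brings in an oxygen and a hydrogen-bond acceptor, and the earlier compounds offered only an isopropyl group on that ring, so the tolerance seen there now extends to a second, different group, though only at the single concentration tested. No supporting evidence is available to explain why the read-out holds for this change.

The compounds shown leave open whether an amine, a carboxylic acid or a longer chain such as butoxy on this aromatic carbon would also stay within the scatter of compound 2. They also leave open whether methoxy on another carbon of the same ring, or a hydroxyl group in its place, would read the same way.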